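A Fluoro Substituent in Place of Hydroxy on the Core

This account rests on a few compounds, and the source may have more. Where it says the series, first, only, none or still open, it means among the compounds named here.

Of the compounds shown here, two have been measured. Compound 2 `C[S+]([O-])/C=C/c1cc(=O)c2cc(O)ccc2o1` is one of them. In a functional assay on DLD-1 cells (Homo sapiens) for cytotoxicity, with a stated time of 48 h (on this read-out higher numbers stand for weaker inhibition and lower numbers for stronger inhibition), compound 2 gives > 10000 nM, which is a limit of the assay and not a number. Compound 1 `CCOc1ccc2oc(/C=C/[S+](C)[O-])cc(=O)c2c1` differs from compound 2 by ethyl in place of hydrogen on an oxygen on an aromatic ring, and in this assay compound 1 gives 4900 nM. Within the data shown here, the single measured step is an at least 2.0-fold higher number from compound 1 to compound 2 (0.30 log units; that floor lies within the scatter); its end point sits at the limit of > 10000 nM in this assay, at which 1 of the 2 values shown sits.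

Compound 3 `C[S+]([O-])/C=C/c1cc(=O)c2cc(F)ccc2o1` has not yet been measured. It differs from compound 2 by fluoro in place of hydroxy on an aromatic carbon. Among the measured compounds shown here, no measured step bears on this change, as the only step recorded concerns ethyl against hydrogen on an oxygen, so the direction cannot be read from the data. The step of a number no higher from compound 2 to compound 3 (the limit leaves the size open) is therefore expected to stay within the scatter. Compound 3 is estimated at 10000 nM, with a range from 3000 nM to 30000 nM.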

Compound 3, half-maximal inhibitory concentration: 7000 nM
For compound 3 the middle estimate is 1.4-fold (0.15 log units) above the measured one, and the stated range covers the measured number.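

Fluoro in place of hydroxy on this aromatic carbon gives an at least 1.4-fold lower number from compound 2 to compound 3 (0.15 log units; that floor lies within the scatter). Going by these compounds, the true size of that step stays open because compound 2 sits at a limit of the assay and not at a number: the limit of > 10000 nM in this assay, at which 1 of the 3 values shown sits. Fluoro in place of ethoxy gives a 1.4-fold higher number from compound 1 to compound 3 (0.15 log units; within the scatter), so in this assay these two groups cannot be told apart at this position, and the ethyl chain on the oxygen is not needed for a measurable number here.

The compounds shown leave open whether an amine, a carboxylic acid or a longer chain such as butoxy on this carbon would move the number beyond the scatter. They also leave open whether fluoro on another carbon of the shared core would give a similar result.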